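Working notes: exchanging the amide side chain of compound 2

The compounds below may be only part of what the source reports. "The series", "measured", "known", "first", "only" and "open" are said of these compounds alone.

Measured in an assay on CHO-K1 cells for displacement of a labelled ligand from melanin-concentrating hormone receptor 1 (Homo sapiens), read by scintillation proximity assay, with a stated time of 2 h; a lower number here means a stronger inhibitor, a higher number a weaker inhibitor:
compound 1, `C/C(=C\C(=O)Nc1ccc2nc(N3CCC(O)CC3)nc(C)c2c1)c1ccc(Cl)cc1`, 670 nM
compound 2, `C/C(=C\C(=O)Nc1ccc2nc(N3CCC(O)(C4CC4)CC3)nc(C)c2c1)c1ccc(Cl)cc1`, 532 nM
compound 3, `COCC(=O)NC1CCN(c2nc(C)c3cc(NC(=O)/C=C/c4ccc(OC(F)(F)F)cc4)ccc3n2)CC1`, 32 nM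

Compound 2 sits second highest of the three numbers. Its nearest neighbour is compound 1, the step being a 1.3-fold lower number from compound 1 to compound 2 (0.10 log units; within the scatter), a change within the scatter. Compound 3 lies beyond the scatter below it.

Compound 4, `COc1ccc(/C=C/C(=O)Nc2ccc3nc(N4CCC(O)(C5CC5)CC4)nc(C)c3c2)cc1`, differs from compound 2 in one place: 2-(4-methoxyphenyl)ethenyl in place of 2-(4-chlorophenyl)prop-1-en-1-yl on a carbonyl carbon. Within the data shown here, no measured single step touches this position; the only one-place step, a 1.3-fold lower number from compound 1 to compound 2 (0.10 log units; within the scatter), concerns the saturated ring and says nothing about the amide side chain. Compound 3 also carries an ethenyl side chain without the extra methyl, yet it differs on the saturated ring as well, so its far lower number can only hint at direction, not size.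

For compound 4 the expected step from compound 2 is a 2.1-fold lower number from compound 2 to compound 4 (0.33 log units; beyond the scatter), toward a lower number, with wide uncertainty. The estimate for compound 4 in this assay is 250 nM, range 60 nM to 1000 nM.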

Compound 4, half-maximal inhibitory concentration: 116 nM
The estimate for compound 4 lay 2.2-fold (0.33 log units) above the measured number; low and high end bracket the measured number.
By their numbers in this assay, from the lowest: compound 3; then compound 4; then compounds 2 and 1 (each within the scatter of the next).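

In this assay the exchange of 2-(4-chlorophenyl)prop-1-en-1-yl for 2-(4-methoxyphenyl)ethenyl on a carbonyl carbon gives a 4.6-fold lower number from compound 2 to compound 4 (0.66 log units; beyond the scatter) and so lies beyond the scatter. The earlier one-place step on the saturated ring, a 1.3-fold lower number from compound 1 to compound 2 (0.10 log units; within the scatter), stayed within it, which makes the amide side chain the first position in this set shown to move the number. The exchange removes the methyl of the chain and replaces chlorine with methoxy in a single step, and nothing measured here gives a reason for the change.

The share of each of these two changes stays open, as the 4-methoxyphenyl group on the methyl-bearing chain and the 4-chlorophenyl group on the ethenyl chain are not among the compounds shown. Also open, going by these compounds, is what an amine or a carboxylic acid in place of the methoxy group would do at this position.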